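This account rests on a few compounds, and the source may have more. Where it says the series, first, only, none or still open, it means among the compounds named here.

In an assay on HEK293 cells for displacement of a labelled ligand from 5-hydroxytryptamine receptor 6 (Homo sapiens), with a stated time of 60 min, tested at 1 uM, in the presence of a further agent that is not named here (a lower number here means a weaker effect, a higher number a stronger effect of the compound at the concentration tested), compound 1 `COc1cc(N)c(Cl)cc1C(=O)CCC1CCN(CCNS(=O)(=O)c2ccc3c(c2)NC(=O)CO3)CC1` gives 40%. Within the data shown here, compound 2 `COc1ccc(S(=O)(=O)NCCN2CCC(CCC(=O)c3cc(Cl)c(N)cc3OC)CC2)cc1OC` gives 58% in this assay, the higher of the two numbers measured, and the step of a number 18 percentage points higher from compound 1 to compound 2 (beyond the scatter) is the only measured step. Compound 3 `COc1cc(N)c(Cl)cc1C(=O)CCC1CCN(CCNS(=O)(=O)c2ccc(N)c(Br)c2)CC1` differs from compound 2 by 4-amino-3-bromophenyl in place of 3,4-dimethoxyphenyl on a sulfonyl sulfur. Among the measured compounds shown here, no measured step makes this same exchange on the sulfonyl sulfur, so the one measured step bears on it only loosely, and a small change in either direction is expected, a number 8 percentage points lower from compound 2 to compound 3 (within the scatter). Compound 3 is therefore estimated at 50% in this assay, between 25% and 75%.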

Compound 3, a percentage reported as inhibition, at one concentration (the size of the read-out at that concentration, not a potency): 85%
The estimate for compound 3 lay 35 percentage points below the measured number, and the stated range ends below it.
By their numbers in this assay, from the lowest: compound 1; then compound 2; then compound 3.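

In this assay, the substituent on the sulfonyl sulfur proves able to move the read-out further than the first step showed: 4-amino-3-bromophenyl gives a number 27 percentage points higher from compound 2 to compound 3 (beyond the scatter) and, against the group of compound 1, a number 45 percentage points higher from compound 1 to compound 3 (beyond the scatter) in the same series. Compound 3, whose group has fewer heavy atoms than either of the others and a hydrogen-bond donor, stands highest of the three. Nothing available accounts for this gain. On these data alone, whether the amine or the bromine drives the step remains open, since the two enter together. As far as these compounds go, how a phenyl bearing only the amine or only the bromine, or chlorine in place of bromine, would read also remains open.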